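Pyridine isomer swap on the amide of compound 3

A few compounds are considered here, and "the series" means these few. Any claim that something is new, unique, unknown or untested is made for them only; others in the source may bear on it.

Compound 3 `O=C(Nc1nnc(-c2ccc3c(c2)OCCO3)s1)c1ccccn1` carries a pyridin-2-yl group on the carbonyl carbon of the shared core. In a functional assay on SW 1116 cells (Homo sapiens) for antiproliferative activity, read by MTT assay, with a stated time of 48 h (on this read-out higher numbers stand for an effect only at larger amounts of compound and lower numbers for an effect already at smaller amounts), compound 3 gives only a limit, > 100 ug/mL. Compound 1 `Cc1ccccc1C(=O)Nc1nnc(-c2ccc3c(c2)OCCO3)s1` also gives only a limit in this assay, > 100 ug/mL. Among the compounds with values here, compound 2 `O=C(Nc1nnc(-c2ccc3c(c2)OCCO3)s1)c1ccc(Cl)nc1`, with 6-chloropyridin-3-yl on the carbonyl carbon, is the one compound of the three with a number, giving 30.4 ug/mL in this assay. Thus (the limit of > 100 ug/mL in this assay, at which 2 of the 3 values shown sit), and compound 3 sits there beside compound 1, with the step that the two limits leave unreadable from compound 1 to compound 3 unreadable, whereas an at least 3.2-fold lower number from compound 1 to compound 2 (0.51 log units; beyond the scatter) and an at least 3.2-fold higher number from compound 2 to compound 3 (0.51 log units; beyond the scatter) are both beyond the scatter.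

Compound 4 `O=C(Nc1nnc(-c2ccc3c(c2)OCCO3)s1)c1ccncc1` differs from compound 3 by pyridin-4-yl in place of pyridin-2-yl on a carbonyl carbon. Within the data shown here, no measured step moves the ring nitrogen within an otherwise unsubstituted pyridine. Among the measured compounds shown here, the only step that touches a pyridine, an at least 3.2-fold higher number from compound 2 to compound 3 (0.51 log units; beyond the scatter), also removes a chloro group, so it does not carry over directly. The change is therefore expected to leave compound 4 in this assay near where compound 3 sits, and the step of a number no higher from compound 3 to compound 4 (the limit leaves the size open) is expected not to go beyond the scatter. Compound 4 is estimated at 100 ug/mL in this assay, within 30 ug/mL to 300 ug/mL, with a fair chance that only a limit is again reported.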

Compound 4, half-maximal effective concentration: > 100 ug/mL
Compound 4: a limit, no number (the forecaster's own chance of this, stated with the estimate: 60%); the middle value sits exactly at the limit.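

With pyridin-4-yl in place of pyridin-2-yl on the carbonyl carbon, this position now holds two unsubstituted pyridine isomers, and in this assay both remain at a limit, as does the 2-methylphenyl group of compound 1: the limit of > 100 ug/mL in this assay, at which 3 of the 4 values shown sit. Each step among compound 1, compound 3 and compound 4 joins two limits and cannot be read, so moving the ring nitrogen has no measurable size here. Within the data shown here, compound 2 remains the only compound with a number, and an at least 3.2-fold higher number from compound 2 to compound 4 (0.51 log units; beyond the scatter) matches the gap already seen with compound 3, which shows that neither unsubstituted pyridine tested reaches the value of compound 2, although this step, too, changes the chloro group and the ring attachment together.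

The compounds shown do not separate the chloro group from the attachment in 6-chloropyridin-3-yl, and plain pyridin-3-yl on the carbonyl carbon would be the direct test of that. From the compounds shown here alone, it also remains open how far compound 1, compound 3 and compound 4 lie past their limits, and whether an amine or a carboxylic acid in place of the chloro group would keep a readable number.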